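From Bromine to Fluorine on the Amide-Type Nitrogen

The source may hold more compounds than are shown below. What is called first, only, known or untested is meant among the compounds shown, and "the series" means these compounds.

Two compounds define the picture so far. Compound 1 `O=C(Nc1ccccc1Br)N1CCN(c2ccnc(Cl)n2)CC1` is measured in an assay on isolated protein for antagonist activity at transient receptor potential cation channel subfamily V member 1 (Homo sapiens) (on this read-out higher numbers stand for weaker inhibition and lower numbers for stronger inhibition), at 1070 nM. Compound 2 `O=C(Nc1cccc(F)c1)N1CCN(c2ccnc(Cl)n2)CC1` carries a 3-fluorophenyl on the amide-type nitrogen in place of the 2-bromophenyl, and in this assay compound 2 gives 952 nM. The two numbers recorded sit within the scatter of each other, so compound 1 stands level with compound 2 rather than apart from it. The step of a 1.1-fold lower number from compound 1 to compound 2 (0.05 log units; within the scatter) is the only one measured and bears directly on the change at hand, since it too exchanges the 2-bromophenyl for a fluorophenyl.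

Compound 3 `O=C(Nc1ccc(F)cc1)N1CCN(c2ccnc(Cl)n2)CC1` differs from compound 1 by 4-fluorophenyl in place of 2-bromophenyl on an amide-type nitrogen. Because the step of a 1.1-fold lower number from compound 1 to compound 2 (0.05 log units; within the scatter) stayed within the scatter, the expectation for compound 3 in this assay is a step of a 1.1-fold lower number from compound 1 to compound 3 (0.03 log units; within the scatter), with no movement beyond the scatter in either direction. Compound 3 is therefore estimated at 1000 nM, within a range from 400 nM to 2500 nM.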

Compound 3, half-maximal inhibitory concentration: 1140 nM
For compound 3 the middle estimate is 1.1-fold (0.06 log units) below the measured one; the measured number falls inside the stated range.
By their numbers in this assay, from the lowest: compounds 2, 1 and 3 (each within the scatter of the next).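

In this assay the 4-fluorophenyl in place of the 2-bromophenyl gives a 1.1-fold higher number from compound 1 to compound 3 (0.03 log units; within the scatter), and the 4-fluorophenyl in place of the 3-fluorophenyl gives a 1.2-fold higher number from compound 2 to compound 3 (0.08 log units; within the scatter). With a second fluorophenyl now read, the 2-bromophenyl, 3-fluorophenyl and 4-fluorophenyl all stand level on the amide-type nitrogen, so none of these three exchanges moves the number beyond the scatter. No independent data accompany these compounds that could account for this levelness.

The compounds shown leave open whether a different substituent on the phenyl ring, such as trifluoromethyl, methoxy or a carboxylic acid, would shift the number beyond the scatter. They also leave open what an amine in place of the chlorine on the shared core would do.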